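This account rests on a few compounds, and the source may have more. Where it says the series, first, only, none or still open, it means among the compounds named here.

Compound 1 `CCOc1ccc(NC2=CC(=O)c3c(nc4n3[C@H]3OC[C@@H](O)[C@H]3OC4)C2=O)cc1` is known in a functional assay on ECa-109 cells for inhibition, with ECa-109 cell line (Homo sapiens) as the target, read by sulforhodamine B assay (a higher number here means a weaker inhibitor, a lower number a stronger inhibitor), only as a limit. In this assay compound 1 gives > 4000 nM, which is a boundary of the assay and not a number, as the limit of > 4000 nM in this assay, at which 1 of the 2 values shown sits, shows. Compound 2 `COc1cccc(NC2=CC(=O)c3nc4n(c3C2=O)[C@H]2OC[C@@H](O)[C@H]2OC4)c1` gives 7620 nM in this assay, so both measured compounds sit at the weak end. Compound 3 `O=C1C(Nc2ccc(Br)cc2)=CC(=O)c2c1nc1n2[C@H]2OC[C@@H](O)[C@H]2OC1` has not yet been measured; it differs from compound 1 in one place: bromo in place of ethoxy on an aromatic carbon. Among the compounds with values here, no measured step compares these two, so the change is expected to move potency no further than the usual scatter, in either direction. Compound 3 is therefore estimated to give 6000 nM in this assay, within 2500 nM to 20000 nM. That estimate means a step that the limit leaves unreadable from compound 1 to compound 3, expected to be small.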

Compound 3, half-maximal inhibitory concentration: 1980 nM
Compound 3: the middle estimate sits 3.0-fold (0.48 log units) above what was measured; the whole stated range lies above it.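

Within the data shown here, with this assay, the first step at this place on the ring is an at least 2.0-fold lower number from compound 1 to compound 3 (0.30 log units; that floor lies within the scatter), with bromo in place of ethoxy. The 4-ethoxyphenyl group can thus give way to 4-bromophenyl, a single bromine atom replacing a chain with an oxygen, with no sign of lost potency. The size of that step can be given only as a floor, and the limit for compound 1 is what sets it: the limit of > 4000 nM in this assay, at which 1 of the 3 values shown sits.

On these data alone, whether other halogens such as chlorine or fluorine would read like bromo stays open. So does the effect of an amine, a carboxylic acid or a longer alkoxy chain at this place.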